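A chloro-to-methoxy swap carried onto a second core

A few compounds are considered here, and "the series" means these few. Any claim that something is new, unique, unknown or untested is made for them only; others in the source may bear on it.

Measured compounds:
compound 1, `Cc1cc(C)c2c(O)cc(-c3ccc(Cl)cc3)nc2n1`: 19500 nM
compound 2, `COc1ccc(-c2cc(O)c3c(C)cc(C)nc3n2)cc1`: 33100 nM
compound 3, `Cc1cnc2nc(-c3ccc(Cl)cc3)cc(O)c2c1`: 3720 nM

In a functional assay on cells (Tumor Cell line, Homo sapiens) for cytotoxicity (a lower number here means a stronger inhibitor of growth, a higher number a weaker inhibitor of growth), compound 3 gives the lowest number of the three, and its gap to compound 1 and to compound 2 is beyond the scatter in each case. How the core of compound 3 differs from the core of compound 1 is not broken down here.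

Within the core of compound 1, the change from compound 1 to compound 2 is methoxy in place of chloro on an aromatic carbon. This gave a 1.7-fold higher number from compound 1 to compound 2 (0.23 log units; within the scatter), a step that stays within the scatter.

Compound 4, `COc1ccc(-c2cc(O)c3cc(C)cnc3n2)cc1`, has not yet been measured. It relates to compound 3 as compound 2 relates to compound 1: the change is methoxy in place of chloro on an aromatic carbon. Both changes are the same, at the same kind of place. Going by the values given here, the only guide to its size is the single earlier step, so the expectation for compound 4 is a step of a 1.7-fold higher number from compound 3 to compound 4 (0.23 log units; within the scatter), resting on a 1.7-fold higher number from compound 1 to compound 2 (0.23 log units; within the scatter) and on the value of compound 3. Compound 4 is therefore estimated at 6300 nM in this assay, expected to lie between 2500 nM and 16000 nM.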

Compound 4, concentration for 50% growth inhibition: 6170 nM
For compound 4 the middle estimate is 1.0-fold (0.01 log units) above the measured one; the measured number falls inside the stated range.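

In this assay, methoxy in place of chloro on an aromatic carbon gave a 1.7-fold higher number from compound 3 to compound 4 (0.22 log units; within the scatter), and this step on the second core agrees with the step on the first: the same change on two cores in this assay, a 1.7-fold higher number (0.23 log units; within the scatter) from compound 1 to compound 2 and a 1.7-fold higher number (0.22 log units; within the scatter) from compound 3 to compound 4, 1.0-fold (0.01 log units) apart, within the scatter of two such steps Across these two cores, then, the change carried over with its size intact, and the earlier step served as a fair guide to the later one. Going by these compounds alone, this does not show that the swap itself has a real effect, as each step lies within the scatter, and agreement between two such small steps, on only two cores, establishes no rule for the wider series.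

The compounds shown leave open whether other groups at the same place, such as an amine, a carboxylic acid or a longer alkoxy chain, would give steps beyond the scatter, and whether such steps would carry from one core to the other as closely. They also leave open whether the agreement would hold on any further core.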